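The source may hold more compounds than are shown below. What is called first, only, known or untested is meant among the compounds shown, and "the series" means these compounds.

Of the compounds shown here, two of a shared core have been tested in a functional assay on HepG2 cells (Homo sapiens) for cytotoxicity, read by MTT assay; a higher number here means a weaker inhibitor, a lower number a stronger inhibitor. Compound 1, with the structure `CC(C)c1ccc2oc(-c3cccc([N+](=O)[O-])c3)cc(=O)c2c1`, returns only a limit in this assay, reported as > 50000 nM. Compound 2, with the structure `O=c1cc(C2CCCCC2)oc2ccc(Cl)cc12`, gives 20000 nM in this assay. Among the compounds with values here, compound 2 therefore stands as the only true number in the set, since the other value recorded for this assay is a limit rather than a measurement, a point made plain by the limit of > 50000 nM in this assay, at which 1 of the 2 values shown sits, where one of the two values sits. Within the data shown here, no step between two measured compounds is available for comparison.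

Compound 3, with the structure `O=c1cc(C2CCCC2)oc2ccc(Cl)cc12`, has not yet been measured in this assay. It differs from compound 2 by cyclopentyl in place of cyclohexyl on an aromatic carbon. For this small change the step from compound 2 to compound 3 is expected to be a 1.3-fold higher number from compound 2 to compound 3 (0.10 log units; within the scatter), which would fall within the usual scatter of repeated measurements in this assay, with no clear direction. Compound 3 is accordingly estimated at 25000 nM, with a range from 10000 nM to 60000 nM.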

Compound 3, half-maximal inhibitory concentration: 13400 nM
Compound 3: middle estimate off by 1.9-fold (0.27 log units), on the high side; measured number inside the range.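

Within the data shown here, the step of a 1.5-fold lower number from compound 2 to compound 3 (0.17 log units; within the scatter) is the first comparison between two compounds of the shared core that differ in one place in this assay, and it concerns the carbon next to the ring oxygen. At this position, a five-membered non-aromatic ring of carbon only in place of a six-membered one leaves the two compounds within the scatter, so the data do not separate cyclopentyl from cyclohexyl in this assay. Both groups have no hydrogen-bond donors or acceptors and no net charge, so the step tests ring size alone, and nothing measured here bears on what lies behind it.

The two compounds leave open whether a different kind of group at this carbon, such as an amine, a carboxylic acid or a longer chain, would move the number beyond the scatter. Compound 1 gives only a limit, > 50000 nM, and it differs from compound 2 and compound 3 in more than one place, so any step to it cannot be read.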